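Swapping 4-methylphenyl for 2-chlorophenyl on a carbonyl carbon

The source may report more compounds than this note shows. Statements on the series, on what has been measured and on what is new or still open speak of the compounds shown alone.

Measured in a functional assay on SGC-7901 cells (Homo sapiens) for antiproliferative activity, read by MTT assay, with a stated time of 24 h; on this read-out higher numbers stand for weaker inhibition and lower numbers for stronger inhibition:
- compound 1 `Cc1cccc(NNC(=O)c2cccc(NS(=O)(=O)c3cnc(O)nc3O)c2)c1`: > 20000 nM (a limit of the assay, not a number)
- compound 2 `O=C(NNc1ccccc1Cl)c1cccc(NS(=O)(=O)c2cnc(O)nc2O)c1`: 2270 nM
- compound 3 `Cc1ccc(C(=O)NNC(=O)c2cccc(NS(=O)(=O)c3cnc(O)nc3O)c2)cc1`: 10100 nM

For the measured compounds named here, only two of these values are true numbers, and compound 3 has the higher of them, so it inhibits more weakly than compound 2. The gap is a 4.4-fold higher number from compound 2 to compound 3 (0.65 log units; beyond the scatter).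

The next compound to be tested is compound 4 `O=C(NNC(=O)c1ccccc1Cl)c1cccc(NS(=O)(=O)c2cnc(O)nc2O)c1`. It differs from compound 3 by one change: 2-chlorophenyl in place of 4-methylphenyl on a carbonyl carbon. In words, 2-chlorophenyl takes the place of 4-methylphenyl on a carbonyl carbon.

The closest guide is the swap of 3-methylphenyl for 2-chlorophenyl on an amine nitrogen, which gave an at least 8.8-fold lower number from compound 1 to compound 2 (0.94 log units; beyond the scatter). That guide is imperfect. The swap sits at a different place, the group leaving is not the same, and its size is only a floor set by a limit. The step of an at least 1.9-fold lower number from compound 1 to compound 3 (0.29 log units; that floor lies within the scatter) says little here, since it involves a different change.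

A smaller step in the same direction therefore seems reasonable, towards stronger inhibition in this assay. The estimate is a 2.9-fold lower number from compound 3 to compound 4 (0.46 log units; beyond the scatter). The expected value for compound 4 is 3500 nM, with an estimated range from 1000 nM to 12000 nM.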

Compound 4, half-maximal inhibitory concentration: 6070 nM
The estimate for compound 4 lay 1.7-fold (0.24 log units) below the measured number, within the range that was stated.
By their numbers in this assay, from the lowest: compound 2; then compounds 4 and 3 (each within the scatter of the next). At a limit, above all of these: compound 1.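

In this assay, putting 2-chlorophenyl in place of 4-methylphenyl on a carbonyl carbon gives a 1.7-fold lower number from compound 3 to compound 4 (0.22 log units; within the scatter), so the two groups, which have the same number of heavy atoms, cannot be told apart at this position. The earlier compounds shown here showed a clear gain with 2-chlorophenyl only on an amine nitrogen, so that gain does not reappear in this carbonyl series, and the two places are linked directly by a 2.7-fold higher number from compound 2 to compound 4 (0.43 log units; beyond the scatter), a real difference in favour of compound 2. The step of an at least 3.2-fold lower number from compound 1 to compound 4 (0.51 log units; beyond the scatter) is beyond the scatter but gives only a floor, set by the limit of compound 1, which is a limit and not a true number: the limit of > 20000 nM in this assay, at which 1 of the 4 values shown sits.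

These two aromatic groups differ in both their substituent and where it sits, so this single pair cannot show whether either feature matters on the carbonyl carbon. Going by these compounds, it also remains open whether a quite different group there, such as an amine, a carboxylic acid or a longer chain, would move the number beyond the scatter.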